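This account rests on a few compounds, and the source may have more. Where it says the series, first, only, none or still open, it means among the compounds named here.

Working notes on the series.

Among the measured compounds shown here, compound 2 `COc1ccc(/C=C/C(=O)c2ccc(NC(=O)C(C)Br)cc2)cc1` has the lower of the two numbers measured so far: in a functional assay on the whole organism (strain albino) for inhibition, with Rattus norvegicus as the target, read by paw edema, with stated times of 30 min and 3 h, at a dose of 100 mg/kg by the oral route (a lower number here means less inhibition, a higher number more inhibition at the dose given (going by the name of the read-out)), compound 2 gives 40%. For the measured compounds named here, its nearest neighbour is compound 1 `COc1ccc(/C=C/C(=O)c2ccc(NC(=O)CO[N+](=O)[O-])cc2)cc1`, and in this assay compound 1 gives 53%; the step of a number 13 percentage points lower from compound 1 to compound 2 (beyond the scatter) is the only measured comparison in hand.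

Compound 3 `COc1ccc(/C=C/C(=O)c2ccc(NC(=O)C(C)O[N+](=O)[O-])cc2)cc1` is not yet measured. Relative to compound 2 the change is nitrooxy in place of bromo on a saturated chain carbon bound to a carbonyl carbon and a saturated chain carbon. Going by the values given here, this is close to the reverse of the one measured step: there, 1-bromoethyl in place of (nitrooxy)methyl on a carbonyl carbon gave a modest fall; here bromo gives way to nitrooxy, while the methyl branch of the chain is kept. Among the compounds with values here, the single step therefore bears directly on the question, and its size is modest. Within the data shown here, compound 3 is expected to sit above compound 2 by about a number 10 percentage points higher from compound 2 to compound 3 (within the scatter), though with only one step behind the reasoning the range is kept wide. Compound 3 is thus estimated at 50% in this assay, between 38% and 62%.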

Compound 3, a percentage reported as inhibition, in the whole organism at one dose (the size of the read-out at that dose, not a potency): 50%
Compound 3: middle estimate and measured number agree at the digits printed, within the range that was stated.
By their numbers in this assay, from the lowest: compounds 2, 3 and 1 (each within the scatter of the next, the first and the last beyond it).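

In this assay, among the compounds shown here, the single step from bromo to nitrooxy on a saturated chain carbon bound to a carbonyl carbon and a saturated chain carbon, with the methyl branch kept, reads as a number 10 percentage points higher from compound 2 to compound 3 (within the scatter) and so does not clear the scatter on its own. The methyl branch can now be read separately within the nitrooxy pair, as a number 3 percentage points lower from compound 1 to compound 3 (within the scatter) for methyl in place of hydrogen, so this change does not clear the scatter either, whereas the earlier step, which altered both features at once, reads as a number 13 percentage points lower from compound 1 to compound 2 (beyond the scatter) and does lie beyond it. For the compounds shown here, the two features are thus separated for the first time, and only their combination gives a gap beyond the scatter, though nothing in hand offers an explanation for these numbers.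

The compounds shown leave open how the bromo group would read on the unbranched chain, which would supply the missing corner of this comparison and test whether the two changes add up. Also open, from the compounds shown here alone, is whether an amine or a hydroxy group on the same carbon, or an ethyl chain in place of the methyl branch, would move the paw edema read-out beyond the scatter.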